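Swapping Fluoro for Methyl: a Change Without a Precedent

The source may hold more compounds than are shown below. What is called first, only, known or untested is meant among the compounds shown, and "the series" means these compounds.

compound 1 `Nc1ccccc1NC(=O)c1ccc(CSC(=S)N2CCN(C3CCCCC3)CC2)cc1`: 31.7%
compound 2 `Nc1ccccc1NC(=O)c1ccc(CSC(=S)N2CCN(c3ccc(F)cc3)CC2)cc1`: 20.9%
compound 3 `Nc1ccccc1NC(=O)c1ccc(CSC(=S)N2CCc3cc(Cl)ccc32)cc1`: 31.9%

Of the compounds shown here, three sharing one core have been tested in a functional assay on A-375 cells (Homo sapiens) for antiproliferative activity, read by CCK-8 assay, with a stated time of 72 h, tested at 2 uM; a lower number here means a weaker effect, a higher number a stronger effect of the compound at the concentration tested. Compound 2 stands lowest of the three, with compound 1 nearest and compound 3 furthest, both higher by amounts beyond the scatter. Within the data shown here, the one measured step, a number 10.8 percentage points lower from compound 1 to compound 2 (beyond the scatter), was modest; it concerns the whole group on the amine nitrogen in the ring, 4-fluorophenyl in place of cyclohexyl.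

Compound 4 `Cc1ccc(N2CCN(C(=S)SCc3ccc(C(=O)Nc4ccccc4N)cc3)CC2)cc1` has not yet been measured. It differs from compound 2 in a single place: methyl in place of fluoro on an aromatic carbon. Among the measured compounds shown here, this is a much smaller change than the one measured step, which exchanged a whole ring. For the measured compounds named here, no measured pair speaks to methyl in place of fluoro on an aromatic carbon, so the direction of any effect is unknown, and the size of the change gives no ground to expect a shift beyond the scatter in this assay.

Compound 4 is therefore expected to give about 22% in this assay, within a range from 10% to 35%. The step of a number 1.1 percentage points higher from compound 2 to compound 4 (within the scatter) that this estimate implies is expected to stay within the usual scatter.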

Compound 4, a percentage reported as inhibition, at one concentration (the size of the read-out at that concentration, not a potency): 25.8%
Estimate against measurement, compound 4: 3.8 percentage points below; measured number inside the range.
By their numbers in this assay, from the lowest: compounds 2, 4, 1 and 3 (each within the scatter of the next, the first and the last beyond it).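

In this assay, among these compounds, the first measured pair for methyl in place of fluoro on an aromatic carbon, para to a large group, gives a number 4.9 percentage points higher from compound 2 to compound 4 (within the scatter), so the two groups cannot be told apart at this position. Replacing cyclohexyl gave a number 10.8 percentage points lower from compound 1 to compound 2 (beyond the scatter) with 4-fluorophenyl, but gives a number 5.9 percentage points lower from compound 1 to compound 4 (within the scatter) with 4-methylphenyl, which shows that an aromatic ring on that amine nitrogen does not always bring a step beyond the scatter. Nothing among the data given here explains these numbers.

From the compounds shown here alone, it remains open whether the same place tolerates groups unlike these two, such as an amine, a carboxylic acid or a longer chain, which could show whether the substituent there matters at all. Every number here also comes from a single concentration, which measures the size of an effect and not a potency, so this assay cannot tell whether compound 2 and compound 4 would still be indistinguishable across a full range of concentrations.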